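The source may hold more compounds than are shown below. What is called first, only, known or untested is meant among the compounds shown, and "the series" means these compounds.

Notes on the series. Compound 1 `COc1ccc(/C=C/C(=O)c2ccccc2-c2ccc(F)cc2)cc1OC` and compound 3 `COc1ccc(C(=O)/C=C/c2ccccc2-c2ccc(F)cc2)cc1OC` are built from the same atoms joined differently; the difference between the two cores is not broken down here. In a functional assay on HepG2 cells (Homo sapiens) for antiproliferative activity, read by sulforhodamine B assay, with a stated time of 48 h (on this read-out higher numbers stand for weaker inhibition and lower numbers for stronger inhibition), compound 1 gives 95 nM. Compound 3 is the weakest of the three measured compounds in this assay, at 6600 nM.

Compound 2 `COc1ccc(/C=C/C(=O)c2ccccc2-c2ccc(F)nc2)cc1OC` carries one change on the core of compound 1: 6-fluoropyridin-3-yl in place of 4-fluorophenyl on an aromatic carbon. In this assay compound 2 gives 1000 nM, so the change brought an 11-fold higher number from compound 1 to compound 2 (1.02 log units; beyond the scatter).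

Compound 4 `COc1ccc(C(=O)/C=C/c2ccccc2-c2ccc(F)nc2)cc1OC` carries the same change on the core of compound 3: 6-fluoropyridin-3-yl in place of 4-fluorophenyl on an aromatic carbon. The place of the change reads the same in both pairs, so this is the same change, now on a different core. It has been measured only once, and the two cores differ in a way that is not broken down here, so whether the step carries over at its full size on the core of compound 3 is open.

The step expected from the change on compound 3 is a 6.8-fold higher number from compound 3 to compound 4 (0.83 log units; beyond the scatter), in the same direction as the measured one and close to it in size. Within the data shown here, this rests on the single measured instance, an 11-fold higher number from compound 1 to compound 2 (1.02 log units; beyond the scatter), and on the starting point of compound 3 at 6600 nM. Compound 4 is therefore expected near 45000 nM in this assay. The estimate for compound 4 is expected to fall between 12000 nM and 150000 nM, a wide span because the step rests on an 11-fold higher number from compound 1 to compound 2 (1.02 log units; beyond the scatter) alone.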

Compound 4, half-maximal inhibitory concentration: 17000 nM
Beside the measured number, compound 4's estimate is 2.6-fold (0.42 log units) above it; the range from low to high includes it.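

In this assay, 6-fluoropyridin-3-yl in place of 4-fluorophenyl on the core of compound 3 gives a 2.6-fold higher number from compound 3 to compound 4 (0.41 log units; beyond the scatter), so the change goes with weaker inhibition on both cores. The direction carries over from one core to the other, but the size does not, and a step read on one core here does not give the step on the other at full size: the same change on two cores in this assay, an 11-fold higher number (1.02 log units; beyond the scatter) from compound 1 to compound 2 and a 2.6-fold higher number (0.41 log units; beyond the scatter) from compound 3 to compound 4, 4.1-fold (0.61 log units) apart, beyond the scatter of two such steps

Among these compounds, these are only two pairs, so they show that the size of this step differs between the two cores, but not which feature of the cores goes with that difference, nor how the change would behave on a third core.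

Still open, as far as these compounds go, is whether other groups at the same place, such as an unsubstituted pyridin-3-yl, a 6-chloropyridin-3-yl or a pyrimidin-5-yl ring, would show the same direction and a similar gap between the two cores. From the compounds shown here alone, it is equally open whether the gap would persist with a different pattern on the dimethoxyphenyl end of the molecule, for instance a single methoxy group or a hydroxy group in place of one methoxy group.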